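Amide-substituted sulfonyl ethyl chains: metabolic stability notes

This account rests on a few compounds, and the source may have more. Where it says the series, first, only, none or still open, it means among the compounds named here.

Measured so far:
compound 1, `CC(C)(C)NC(=O)NCCS(=O)(=O)NC(=O)c1ccc(Nc2nc(NC3(c4ccc(Cl)cc4)CC3)nc(OCC(F)(F)F)n2)cc1`, an ADME assay on microsomes from liver (Rattus norvegicus) for metabolic stability, with a stated time of 10 min; on this read-out higher numbers stand for a more stable compound and lower numbers for a less stable compound: 93%
compound 2, `CC(C)(C)OC(=O)NCCS(=O)(=O)NC(=O)c1ccc(Nc2nc(NC3(c4ccc(Cl)cc4)CC3)nc(OCC(F)(F)F)n2)cc1`, this assay: 93%
compound 3, `CCS(=O)(=O)NC(=O)c1ccc(Nc2nc(NC3(c4ccc(Cl)cc4)CC3)nc(OCC(F)(F)F)n2)cc1`, this assay: 85%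

Compound 3 gives 85% in this assay; the steps of a number 8 percentage points lower from compound 1 to compound 3 (within the scatter) and a number 8 percentage points lower from compound 2 to compound 3 (within the scatter) both lie within the scatter, so the three measured compounds are not told apart on this read-out. Compound 4, `O=C(NS(=O)(=O)CCNC(=O)C1CC1)c1ccc(Nc2nc(NC3(c4ccc(Cl)cc4)CC3)nc(OCC(F)(F)F)n2)cc1`, carries the change ((cyclopropylcarbonyl)amino in place of hydrogen on a saturated chain carbon, two bonds along the chain from a sulfonyl sulfur). The two steps above bear on it directly, each placing a ((tert-butyl)carbamoyl)amino or (tert-butoxycarbonyl)amino group at the same chain carbon, and neither moved this assay beyond the scatter. The step of a number 5 percentage points higher from compound 3 to compound 4 (within the scatter) is therefore expected to stay within the scatter, with no direction worth stating. Compound 4 is estimated at 90%, range 78% to 98%.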

Compound 4, percent of the compound remaining: "not active" (no number reported)
For compound 4 the study gives words and no number; no gap can be computed for the estimate.
By their numbers in this assay, from the lowest: compounds 3, 1 and 2 (each within the scatter of the next).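

Going by these compounds alone, compound 4 is reported in this assay only as "not active", without a number, so no step to compound 4 from compound 1, compound 2 or compound 3 can be read. No measured evidence bears on this result. The compounds shown leave open how (cyclopropylcarbonyl)amino on this chain carbon compares numerically with the groups in compound 1 and compound 2.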